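Trifluoromethyl to methyl on the shared core

This account rests on a few compounds, and the source may have more. Where it says the series, first, only, none or still open, it means among the compounds named here.

Values in a functional assay on Bel-7402 cells (Homo sapiens) for antiproliferative activity, read by MTT assay, with a stated time of 72 h; a lower number here means a stronger inhibitor, a higher number a weaker inhibitor
- Compound 1 `COc1cccc(CNCc2c(C(=O)O)n(Cc3ccc(C)cc3)c3cc(C)ccc23)c1` gives 5670 nM
- Compound 2 `COc1cccc(CNCc2c(C(=O)O)n(Cc3ccccc3F)c3cc(C)ccc23)c1` gives > 50000 nM (a limit)
- Compound 3 `COc1ccc(Cn2c(C(=O)O)c(CNCc3cccc(OC)c3)c3ccc(C(F)(F)F)cc32)cc1` gives > 50000 nM (a limit)

Compound 3 gives no number in this assay and stands at the limit of > 50000 nM in this assay, at which 2 of the 3 values shown sit, so any step from it starts at a limit. Compound 4 `COc1ccc(Cn2c(C(=O)O)c(CNCc3cccc(OC)c3)c3ccc(C)cc32)cc1` carries methyl in place of trifluoromethyl on an aromatic carbon and is otherwise unchanged. Going by the values given here, no measured step covers this change. Among the compounds with values here, the one measured step is an at least 8.8-fold higher number from compound 1 to compound 2 (0.94 log units; beyond the scatter) and it lies at another place, though both of its compounds carry the incoming methyl. Compound 1 reaches 5670 nM with that methyl, which points to a fall in the number. Compound 2 goes against this with > 50000 nM, which is a limit of the assay. The expected change is an at least 3.3-fold lower number from compound 3 to compound 4 (0.52 log units; beyond the scatter) and it is only loosely supported. The estimate for compound 4 is 15000 nM with an expected range of 4000 nM to 50000 nM in this read-out.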

Compound 4, half-maximal inhibitory concentration: 9830 nM
The estimate for compound 4 lay 1.5-fold (0.18 log units) above the measured number, within the range that was stated.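

Within this assay the change from trifluoromethyl to methyl on this aromatic carbon gives an at least 5.0-fold lower number from compound 3 to compound 4 (0.70 log units; beyond the scatter) and so brings the value off the limit. With methyl on the core, 4-methoxyphenyl in place of 2-fluorophenyl gives an at least 5.0-fold lower number from compound 2 to compound 4 (0.70 log units; beyond the scatter) while methoxy in place of methyl gives a 1.7-fold higher number from compound 1 to compound 4 (0.24 log units; within the scatter) and stays within the scatter. The steps from compound 2 and compound 3 start at a limit and fix only a lower bound on size: the limit of > 50000 nM in this assay, at which 2 of the 4 values shown sit.

Open, from the compounds shown here alone, is whether a chlorine atom, a nitrile or a longer chain on this aromatic carbon would match compound 4. A plain hydrogen there would show whether methyl itself matters.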